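Methoxyphenyl to dichlorophenyl: expected shift in cell toxicity

This account rests on a few compounds, and the source may have more. Where it says the series, first, only, none or still open, it means among the compounds named here.

Of the compounds shown here, three sharing one core have been tested in a functional assay on A549 cells (Homo sapiens) for cytotoxicity, read by colorimetric assay and MTT assay, with a stated time of 3 days, tested at 1 uM; a higher number here means a weaker effect of the compound at the concentration tested, a lower number a stronger effect. Compound 1 `COc1ccc(-c2nc(-c3ccccc3)c(-c3ccc4c(c3)NC(=O)CO4)[nH]2)cc1` gives 101%. Compound 2 `COc1ccc(-n2cc(-c3ccccc3)c(-c3ccc4c(c3)NC(=O)CO4)n2)cc1` gives 95.6%, and compound 3 `O=C1COc2ccc(-c3nn(-c4ccc(Cl)cc4)cc3-c3ccccc3)cc2N1` gives 84.4%. Among these three numbers compound 2 stands second highest; its value and that of compound 1 lie within the scatter of each other, while the gap to compound 3 lies beyond it. For the measured compounds named here, the only step between measured compounds that changes a single place is a number 11.2 percentage points lower from compound 2 to compound 3 (beyond the scatter), which came from a chloro in place of a methoxy on an aromatic carbon.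

The unmeasured compound 4 `O=C1COc2ccc(-c3nn(-c4cc(Cl)cc(Cl)c4)cc3-c3ccccc3)cc2N1` differs from compound 2 in one place: 3,5-dichlorophenyl in place of 4-methoxyphenyl on an aromatic nitrogen. The 3,5-dichlorophenyl that enters has no hydrogen-bond acceptor, whereas the 4-methoxyphenyl that leaves had one.

Going by the values given here, the step from compound 2 to compound 3 is the one measured change that bears on this, since it too trades a methoxy for a chloro on an aromatic carbon, and it was modest. A lowering of similar or somewhat larger size is therefore expected in this assay, namely a number 13.6 percentage points lower from compound 2 to compound 4 (beyond the scatter). Compound 4 is estimated at 82%, with a range from 65% to 98%.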

Compound 4, a percentage reported as activity, at one concentration (the size of the read-out at that concentration, not a potency): 93.1%
Compound 4: the middle estimate sits 11.1 percentage points below what was measured, and the stated range covers the measured number.
By their numbers in this assay, from the lowest: compounds 3, 4, 2 and 1 (each within the scatter of the next, the first and the last beyond it).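

On the aromatic nitrogen of the five-membered ring, 3,5-dichlorophenyl in place of 4-methoxyphenyl gives a number 2.5 percentage points lower from compound 2 to compound 4 (within the scatter) in this assay, so at this position a group with no hydrogen-bond acceptor can replace one that has one without a change that can be read. Set against 4-chlorophenyl, the same group gives a number 8.7 percentage points higher from compound 3 to compound 4 (within the scatter), which is also too small to read, even though a number 11.2 percentage points lower from compound 2 to compound 3 (beyond the scatter) had shown a real step; compound 4 therefore sits within the scatter of both neighbours, and the presence of chlorine on this ring does not by itself carry the step seen with compound 3. No measurement at hand explains why these three rings on the nitrogen compare as they do.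

What the compounds shown leave open is how this position would respond to a quite different group, such as a phenyl ring bearing an amine or a carboxylic acid, or a longer alkyl chain in place of the ring. Also open is whether the small differences among these compounds would persist at higher concentrations, since only a single concentration is reported here.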